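A Fluorinated Methoxy Variant of an Inactive Alkyne Amide

A few compounds are considered here, and "the series" means these few. Any claim that something is new, unique, unknown or untested is made for them only; others in the source may bear on it.

Three compounds share one core and differ only in the group on the outer aromatic ring of the alkyne. Compound 1 `O=C(c1ccc(C#Cc2ccc(Oc3ccccc3)cc2)cc1)N1CCC[C@@H](CO)C1` carries a phenoxy group, compound 2 `CSc1ccc(C#Cc2ccc(C(=O)N3CCC[C@@H](CO)C3)cc2)cc1` a methylsulfanyl group, and compound 3 `CCOc1ccc(C#Cc2ccc(C(=O)N3CCC[C@@H](CO)C3)cc2)cc1` an ethoxy group. In a functional assay on TREX cells for negative allosteric modulation of metabotropic glutamate receptor 3 (Rattus norvegicus), read by calcium flux, with a stated time of 2.5 min (a lower number here means a stronger inhibitor, a higher number a weaker inhibitor), compound 3 gives only a limit, > 10000 nM. In this assay compound 1 likewise returns a limit, > 10000 nM. In this assay compound 2 also returns a limit, > 10000 nM. Compound 3 thus stands at the same limit as its two neighbours, and the steps a step that the two limits leave unreadable from compound 1 to compound 2, a step that the two limits leave unreadable from compound 1 to compound 3 and a step that the two limits leave unreadable from compound 2 to compound 3 cannot be sized because all three values sit at the limit of > 10000 nM in this assay, at which 3 of the 3 values shown sit.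

Compound 4 `COc1ccc(C#Cc2ccc(C(=O)N3CCC[C@@H](CO)C3)cc2)cc1F` differs from compound 3 by 3-fluoro-4-methoxyphenyl in place of 4-ethoxyphenyl on a triple-bonded carbon. Among the compounds with values here, no measured step around compound 3 was readable, so nothing argues for a move beyond the scatter. The step from compound 3 to compound 4 is therefore expected to be a number no higher from compound 3 to compound 4 (the limit leaves the size open). Compound 4 in this assay is estimated at 10000 nM, within a range from 3000 nM to 30000 nM, most likely reported again as a limit.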

Compound 4, half-maximal inhibitory concentration: > 10000 nM
Compound 4 ended at the assay's limit (the forecaster's own chance of this, stated with the estimate: 70%); the middle value sits exactly at the limit.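

Compound 4 returns only a limit, as do compound 2 and compound 3, so neither step to compound 4 can be read: the limit of > 10000 nM in this assay, at which 4 of the 4 values shown sit.

The compounds shown leave open whether any group on the outer aromatic ring of the shared core gives a measurable value in this assay.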